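Extending the Amide Substituent Beyond Compound 2

This account rests on a few compounds, and the source may have more. Where it says the series, first, only, none or still open, it means among the compounds named here.

In a functional assay on A549 cells (Homo sapiens) for antiproliferative activity, read by sulforhodamine B assay, with a stated time of 48 h (on this read-out lower numbers stand for stronger inhibition and higher numbers for weaker inhibition), compound 2 (`COc1ccccc1N1C(=O)CSC1c1cccc(C(=O)Nc2ccccc2)c1`) gives > 25000 nM, which is a limit and not a number. Compound 1 (`CCN(CC)C(=O)c1cccc(C2SCC(=O)N2c2ccccc2OC)c1`) gives > 50000 nM, and this too is a limit. Among the measured compounds shown here, the only measured step, a step that the two limits leave unreadable from compound 1 to compound 2, therefore has no readable size, and neither compound offers a number from which to work.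

Compound 3 (`COc1ccccc1N1C(=O)CSC1c1cccc(C(=O)NCCCc2ccccc2)c1`) carries 3-phenylpropyl in place of phenyl on an amide-type nitrogen. No measured step sizes this change in this assay, so no firm direction can be expected, and the most likely outcome is a result near the limits already seen. The expected change is a step that the limit leaves unreadable from compound 2 to compound 3, an estimate with little evidence behind it. Compound 3 is estimated at 30000 nM. Its expected range runs from 8000 nM to 100000 nM.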

Compound 3, half-maximal inhibitory concentration: 31600 nM
The estimate for compound 3 lay 1.1-fold (0.02 log units) below the measured number; the range from low to high includes it.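

Among the compounds shown, only compound 3 gives a number rather than a limit in this assay, so 3-phenylpropyl on the amide-type nitrogen brings the series onto a readable part of the scale. Setting (3-phenylpropyl)amino in place of diethylamino gives an at least 1.5-fold lower number from compound 1 to compound 3 (0.19 log units; that floor lies within the scatter) and so establishes no real gain over the diethylamino amide. The step between the phenyl and 3-phenylpropyl amides cannot be read because compound 2 stands at a limit: the limit of > 25000 nM in this assay, at which 1 of the 3 values shown sits.

From the compounds shown here alone, it remains open whether benzyl, 2-phenylethyl or a longer chain ending in phenyl on the same nitrogen would lower the number further. Also unresolved is whether an amine or a carboxylic acid at the end of the chain, in place of the phenyl ring, would keep a readable value.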